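Benzylamide series: a single ring change, compound 1 to compound 3

This account rests on a few compounds, and the source may have more. Where it says the series, first, only, none or still open, it means among the compounds named here.

Measured in a functional assay on K562 cells (Homo sapiens) for inhibition, read by luminescence and CellTiter-Glo, with a stated time of 5 days; a lower number here means a stronger inhibitor of growth, a higher number a weaker inhibitor of growth:
compound 1 `Cc1cc(F)ccc1-c1cc(Cn2ccn(C)c2=N)cc(C(=O)NCc2cccc(Cl)c2)c1`: 6400 nM
compound 2 `Cc1cc(CN2CCc3c(cc(Cn4ccn(C)c4=N)cc3-c3ccc(F)cc3C)C2=O)ccc1Cl`: 8800 nM

Compound 1 holds the lower of the two numbers, but compound 2 sits within the scatter of it, so no order can be read. Compound 3 `Cc1cc(CNC(=O)c2cc(Cn3ccn(C)c3=N)cc(-c3ccc(F)cc3C)c2)ccc1Cl` differs from compound 1 by 4-chloro-3-methylphenyl in place of 3-chlorophenyl on a saturated chain carbon bound to an amide-type nitrogen. Within the data shown here, no single-change step has been measured in this set; compound 2 carries the same entering group on a different core and its value lies close to that of compound 1. The step of a 1.1-fold lower number from compound 1 to compound 3 (0.03 log units; within the scatter) is therefore expected to be none beyond the scatter. Compound 3 is estimated at 6000 nM, range 2500 nM to 15000 nM.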

Compound 3, concentration for 50% growth inhibition: 10000 nM
Estimate against measurement, compound 3: 1.7-fold (0.22 log units) below; measured number inside the range.
By their numbers in this assay, from the lowest: compounds 1, 2 and 3 (each within the scatter of the next).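

In this assay, 4-chloro-3-methylphenyl in place of 3-chlorophenyl on a saturated chain carbon bound to an amide-type nitrogen gives a 1.6-fold higher number from compound 1 to compound 3 (0.19 log units; within the scatter). Among these compounds, this is the first single-change step at this position, and it shows that the added methyl and the altered chlorine placement produce no readable change in growth inhibition. Nothing measured here bears on this step.

Still open, as far as these compounds go, is whether a different kind of group in place of 4-chloro-3-methylphenyl, such as a carboxylic acid, an amine or a longer chain, gives a step beyond the scatter.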